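Hydroxy on compound 2: expected effect on tolerance

This account rests on a few compounds, and the source may have more. Where it says the series, first, only, none or still open, it means among the compounds named here.

Compound 2 `O=C(Nc1ccccc1)c1cc(Br)cc(Br)c1` reads > 100000 nM in an ADME assay on HEK293 cells (Homo sapiens) for cytotoxicity, read by reporter gene assay and resazurin assay, with a stated time of 48 h (a higher number here means that more compound is tolerated, a lower number that less compound is tolerated), a limit of the assay and not a number. Compound 3 `O=C(Nc1ccccc1)c1cc(Br)cc(Br)c1O` differs from it by hydroxy in place of hydrogen on an aromatic carbon, with hydroxy in place of hydrogen on an aromatic carbon. For the measured compounds named here, no measured step shows this change. Going by the values given here, the only numerical reference is compound 1 `O=C(Nc1cccc(Cl)c1)c1cc(Br)cc(Br)c1O`, which gives 18000 nM in this assay, so a clear step beyond the scatter towards lower tolerated concentrations is expected. The expected size is an at least 3.3-fold lower number from compound 2 to compound 3 (0.52 log units; beyond the scatter). For compound 3 the estimate is 30000 nM, with an expected range of 10000 nM to 90000 nM.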

Compound 3, half-maximal cytotoxic concentration: 34000 nM
For compound 3 the middle estimate is 1.1-fold (0.05 log units) below the measured one; measured number inside the range.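

In this assay, for the compounds shown here, hydroxy in place of hydrogen on the aromatic carbon gives an at least 2.9-fold lower number from compound 2 to compound 3 (0.46 log units; beyond the scatter), the first reading of this change. Compound 2 stands at a limit of the assay and not at a number, so that step is only a bound: the limit of > 100000 nM in this assay, at which 1 of the 3 values shown sits. Hydrogen in place of chloro on the other aromatic ring gives a 1.9-fold higher number from compound 1 to compound 3 (0.28 log units; within the scatter), so with the hydroxy present, this chloro makes no difference beyond the scatter.

On these data alone, whether the lower tolerance is specific to hydroxy at this carbon, or would also follow with an amine or methoxy there, remains open.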